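The source may hold more compounds than are shown below. What is called first, only, known or untested is meant among the compounds shown, and "the series" means these compounds.

Two measured urea compounds frame the question. Compound 1 `Nc1nccc(N2CC[C@H](NC(=O)Nc3ccc(Cl)c(C(F)(F)F)c3)C2)n1` carries the shared core with an amino group on its aromatic ring; in an assay on a protein complex for displacement of a labelled ligand from CDK8/Cyclin C (Homo sapiens), read by TR-FRET, with a stated time of 1 h (on this read-out lower numbers stand for stronger inhibition and higher numbers for weaker inhibition), compound 1 gives 42.3 nM, the higher of the two numbers at hand. Going by the values given here, compound 2 `CNc1ncc(Oc2cccc(NC(=O)Nc3ccc(Cl)c(C(F)(F)F)c3)c2)c(N)n1` gives 14.6 nM in this assay, a lower number than that of compound 1 by a margin beyond the usual scatter; no single-point step connects these two structures, so they stand only as values side by side. Compound 3 `O=C(Nc1ccc(Cl)c(C(F)(F)F)c1)N[C@H]1CCN(c2ccnc(NC3CC3)n2)C1` has not yet been measured in this assay. It departs from compound 1 by one change: cyclopropyl in place of hydrogen on a nitrogen on an aromatic ring. Among the compounds with values here, with no measured step of this kind to lean on, the expectation is a step of a 1.4-fold lower number from compound 1 to compound 3 (0.15 log units; within the scatter), small and downward, within or only just beyond the scatter. Compound 3 is therefore estimated to give 30 nM, with a range from 10 nM to 90 nM.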

Compound 3, half-maximal inhibitory concentration: 20.3 nM
Compound 3: middle estimate off by 1.5-fold (0.17 log units), on the high side; the range from low to high includes it.
By their numbers in this assay, from the lowest: compounds 2 and 3 (each within the scatter of the next); then compound 1.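

In this assay, the amino group on the aromatic ring now has its first measured change: cyclopropyl in place of hydrogen on that nitrogen brings a 2.1-fold lower number from compound 1 to compound 3 (0.32 log units; beyond the scatter) and marks this as a modest step. The nitrogen therefore takes a substituent here, and with this group the number moves down rather than up. Neither earlier value could show this. Going by these compounds alone, no single-point step joined them. Nothing in the data shown explains why this step goes downward or why it has this size.

Whether the ring of cyclopropyl matters remains open, since the compounds shown do not include an ethyl group, a cyclobutyl ring or a longer chain on this nitrogen. From the compounds shown here alone, it is also open how a carboxylic acid or a further amine carried on such a chain would change the number in this assay.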